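Methylating the phenolic oxygen of compound 3

The compounds below may be only part of what the source reports. "The series", "measured", "known", "first", "only" and "open" are said of these compounds alone.

Compound 3 `CCCCCCCCCCCOc1ccc(O)cc1C(SCCC(=O)O)SCCC(=O)O` gives 156 nM in an assay on membranes from lung (Cavia porcellus) for binding affinity to cysteinyl leukotriene receptor (Homo sapiens) (on this read-out lower numbers stand for stronger inhibition and higher numbers for weaker inhibition), the lowest of the three numbers in hand. Within the data shown here, compound 1 `CCCCCCCCCCCOc1ccccc1C(SCCC(=O)O)SCCC(=O)O` gives 287 nM in this assay, and the only single-point step in the set, a 1.8-fold lower number from compound 1 to compound 3 (0.26 log units; within the scatter), stays within the scatter. Among the measured compounds shown here, compound 2 `CCCCCCCCCCCCc1ccccc1C(SCCC(=O)O)[S+]([O-])CCC(=O)O` gives 423 nM in this assay, beyond the scatter from compound 3, but no single-point step connects it to the others.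

Compound 4 `CCCCCCCCCCCOc1ccc(OC)cc1C(SCCC(=O)O)SCCC(=O)O` differs from compound 3 by methyl in place of hydrogen on an oxygen on an aromatic ring. For the measured compounds named here, no measured step touches that oxygen once it is present; the nearest precedent is the arrival of the hydroxy group itself, a 1.8-fold lower number from compound 1 to compound 3 (0.26 log units; within the scatter), which did not move the number beyond the scatter. In this assay the expectation is therefore no step beyond the scatter, with a 1.3-fold higher number from compound 3 to compound 4 (0.11 log units; within the scatter) as the estimated change. Compound 4 is expected to give 200 nM, within an estimated range of 90 nM to 450 nM.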

Compound 4, inhibition constant: 579 nM
For compound 4 the middle estimate is 2.9-fold (0.46 log units) below the measured one, and the stated range ends below it.
By their numbers in this assay, from the lowest: compounds 3, 1, 2 and 4 (each within the scatter of the next, the first and the last beyond it).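

In this assay, among these compounds, the methyl on the phenolic oxygen gives a 3.7-fold higher number from compound 3 to compound 4 (0.57 log units; beyond the scatter) and is the first single-place step to pass beyond the scatter, so this oxygen does register in the read-out once its hydrogen is replaced. Neither group separates from the parent by itself: a 1.8-fold lower number from compound 1 to compound 3 (0.26 log units; within the scatter) and a 2.0-fold higher number from compound 1 to compound 4 (0.30 log units; within the scatter) both stay within the scatter, and only hydroxy and methoxy differ clearly from each other. No measurement shown here bears on the reason for this step.

Still open, on these data alone, is whether a longer chain on this oxygen, such as ethoxy, would carry the number further in the same direction as methoxy. An amine or a carboxylic acid on the same aromatic carbon would show whether hydroxy is unusual among groups at this place.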